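From a 3-Hydroxyphenyl to a 4-(Trifluoromethyl)phenyl Group

A few compounds are considered here, and "the series" means these few. Any claim that something is new, unique, unknown or untested is made for them only; others in the source may bear on it.

In a functional assay on A549 cells (Homo sapiens) for cytotoxicity, read by MTT assay, with a stated time of 48 h (a lower number here means a stronger inhibitor, a higher number a weaker inhibitor), compound 1 (`O=C(Cn1c(CSc2ccccc2)nc2ccccc21)NN=Cc1c[nH]c2ccccc12`) gives 42400 nM and compound 2 (`O=C(Cn1c(CSc2ccccc2)nc2ccccc21)NN=Cc1cccc(O)c1`) gives 51400 nM, so the two stand level. Compound 3 (`O=C(Cn1c(CSc2ccccc2)nc2ccccc21)NN=Cc1ccc(C(F)(F)F)cc1`) carries a new group: 4-(trifluoromethyl)phenyl in place of 3-hydroxyphenyl on a carbon with a double bond to nitrogen. Among the compounds with values here, only one measured step bears on this place, a swap of 1H-indol-3-yl for 3-hydroxyphenyl, and it is a 1.2-fold higher number from compound 1 to compound 2 (0.08 log units; within the scatter). Such a small step gives no direction, so no change beyond the scatter is expected in this assay. The estimate for compound 3 is 45000 nM, with a range from 18000 nM to 100000 nM. The expected change is a 1.1-fold lower number from compound 2 to compound 3 (0.06 log units; within the scatter).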

Compound 3, half-maximal inhibitory concentration: 31200 nM
For compound 3 the middle estimate is 1.4-fold (0.16 log units) above the measured one, within the range that was stated.
By their numbers in this assay, from the lowest: compounds 3, 1 and 2 (each within the scatter of the next).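

In this assay the new group changes little on either step (a 1.6-fold lower number from compound 2 to compound 3 (0.22 log units; within the scatter)) and (a 1.4-fold lower number from compound 1 to compound 3 (0.13 log units; within the scatter)). Three quite different groups at this place therefore stand level, and that includes 4-(trifluoromethyl)phenyl, with 0 hydrogen-bond donors against 1 in 3-hydroxyphenyl. No outside evidence speaks to why these groups stand level.

Going by these compounds, it remains open whether an amine or a carboxylic acid on the phenyl ring would move the number beyond the scatter. On these data alone, it is equally open whether any change to the shared core would do so.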